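Bromo to ethynyl on the anilino ring in the cytotoxicity series

The compounds below may be only part of what the source reports. "The series", "measured", "known", "first", "only" and "open" are said of these compounds alone.

Three compounds of this series have been run in a functional assay on HeLa cells (Homo sapiens) for cytotoxicity, read by resazurin assay; a higher number here means a weaker inhibitor, a lower number a stronger inhibitor. Compound 2 `Nc1ccccc1NC(=O)c1ccc(COc2ccc3ncnc(Nc4cccc(Br)c4)c3c2)cc1` gives 1450 nM. Compound 3 `C#Cc1cccc(Nc2ncnc3cc(NC(=O)c4ccc(C(=O)Nc5ccccc5N)nc4)ccc23)c1` gives 1500 nM, which is indistinguishable from compound 2 within the usual scatter. Compound 1 `C#Cc1cccc(Nc2ncnc3ccc(S(=O)(=O)n4ccc(/C=C/C(=O)Nc5ccccc5N)c4)cc23)c1` gives 3450 nM, a higher number than compound 2 and a gap beyond the scatter; compound 2 thus has the lowest number of the three, but only compound 1 sits clearly apart from it.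

Compound 4 `C#Cc1cccc(Nc2ncnc3ccc(OCc4ccc(C(=O)Nc5ccccc5N)cc4)cc23)c1` has not yet been measured in this assay. It differs from compound 2 in one place: ethynyl in place of bromo on an aromatic carbon. Among the compounds with values here, no measured pair shows this change by itself, so its size is not known. Compounds 1 and 3 both carry the ethynyl group and span the values seen so far, giving no sign that the group alone moves the number far in either direction. Compound 4 is therefore expected to land close to compound 2, with the step of a 1.1-fold higher number from compound 2 to compound 4 (0.04 log units; within the scatter) estimated as none beyond the scatter. The estimate for compound 4 in this assay is 1600 nM, with a range of 700 nM to 3600 nM.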

Compound 4, half-maximal inhibitory concentration: 1350 nM
Compound 4: the middle estimate sits 1.2-fold (0.07 log units) above what was measured; measured number inside the range.
By their numbers in this assay, from the lowest: compounds 4, 2 and 3 (each within the scatter of the next); then compound 1.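

In this assay, within the data shown here, this is the first pair in which ethynyl replaces bromo with nothing else altered, and it gives a 1.1-fold lower number from compound 2 to compound 4 (0.03 log units; within the scatter). On this scaffold, 3-bromophenyl and 3-ethynylphenyl therefore cannot be told apart at this position, something compounds 1 and 3 could not show, as their ethynyl group comes with other differences in the molecule. No measured property bears on why the two groups read alike.

Open, as far as these compounds go, is whether an amine, a carboxylic acid or a longer alkyl chain on this aromatic carbon would also stay within the scatter of compound 2. Also open is whether the bromo to ethynyl change would read the same with the side chains of compound 1 and compound 3, as no bromo partner for either is shown.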